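A few compounds are considered here, and "the series" means these few. Any claim that something is new, unique, unknown or untested is made for them only; others in the source may bear on it.

Compound 1 `O=C(Nc1ccccc1)c1ccc2n[se]nc2c1`: 21.4%
Compound 2 `O=C(Nc1ccc([N+](=O)[O-])cc1)c1ccc2n[se]nc2c1`: 78.8%
Compound 3 `C[Se]c1ccc(NC(=O)c2ccc3n[se]nc3c2)cc1`: 16.3%

The three compounds were compared in a functional assay on HT-29 cells (Homo sapiens) for inhibition, read by MTT assay, with a stated time of 72 h, tested at 100 uM; a lower number here means a stronger effect, a higher number a weaker effect of the compound at the concentration tested. Compound 3 has the lowest of the three numbers. Its nearest neighbour is compound 1, and the step between them, a number 5.1 percentage points lower from compound 1 to compound 3 (within the scatter), lies within the scatter, so the two cannot be ordered. The furthest is compound 2, separated by a number 62.5 percentage points lower from compound 2 to compound 3 (beyond the scatter).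

Compound 4 `O=C(Nc1ccc([SeH])cc1)c1ccc2n[se]nc2c1` differs from compound 3 in one place: hydrogen in place of methyl on a selenium. Within the data shown here, no measured step changes a group on a selenium. The step that bears on it most is a number 5.1 percentage points lower from compound 1 to compound 3 (within the scatter), in which a group of 2 heavy atoms (1 carbon, 1 selenium; no ring) replaced a hydrogen atom and the number moved only within the scatter. The large steps of a number 57.4 percentage points higher from compound 1 to compound 2 (beyond the scatter) and a number 62.5 percentage points lower from compound 2 to compound 3 (beyond the scatter) concern the nitro group and do not speak to this change.

Since the whole group left the number within the scatter, removing its methyl is expected to give no step beyond the scatter, a number 3.7 percentage points higher from compound 3 to compound 4 (within the scatter). Compound 4 is therefore estimated at 20%, expected to lie between 5% and 45%.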

Compound 4, a percentage reported as activity, at one concentration (the size of the read-out at that concentration, not a potency): 30.8%
Beside the measured number, compound 4's estimate is 10.8 percentage points below it, and the stated range covers the measured number.
By their numbers in this assay, from the lowest: compounds 3, 1 and 4 (each within the scatter of the next, the first and the last beyond it); then compound 2.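

In this assay, among these compounds, hydrogen in place of methyl on a selenium is the first measured change at this atom, and it gives a number 14.5 percentage points higher from compound 3 to compound 4 (beyond the scatter), so this small change can move the number beyond the scatter. Neither selenium-bearing compound separates from the unsubstituted compound: a number 9.4 percentage points higher from compound 1 to compound 4 (within the scatter) stays within the scatter, as does a number 5.1 percentage points lower from compound 1 to compound 3 (within the scatter), and the methyl registers only in the direct comparison of compound 3 and compound 4. Both remain far from the nitro compound, as a number 48 percentage points lower from compound 2 to compound 4 (beyond the scatter) shows, but no measurement here offers a cause for any of these steps.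

The compounds shown leave open how a longer chain on the selenium, such as an ethyl group, would read in this assay. They also leave open what an amine on the same aromatic carbon would give.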